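Swapping an amino linker for a sulfanyl one

The source may report more compounds than this note shows. Statements on the series, on what has been measured and on what is new or still open speak of the compounds shown alone.

Three compounds share one core. Compound 1 `CCOc1cc(C)cc2c1C(=O)C=C(c1c(C)cc3c(c1OCC)C(=O)C=CC3=O)C2=O` gives 1070 nM in a functional assay on A-375 cells (Homo sapiens) for cytotoxicity, read by MTT assay, with a stated time of 24 h (a lower number here means a stronger inhibitor, a higher number a weaker inhibitor), compound 3 `CCOc1cc(C)cc2c1C(=O)C=C(c1c(C)cc3c(c1OCC)C(=O)C(NCCO)=CC3=O)C2=O` gives 70 nM, and compound 2 `COc1cc(C)cc2c1C(=O)C=C(c1c(C)cc3c(c1OC)C(=O)C(NCCO)=CC3=O)C2=O` gives 3180 nM, the highest of the three numbers. Among the compounds with values here, the only step known in one place, a 15-fold lower number from compound 1 to compound 3 (1.18 log units; beyond the scatter), concerns adding the (2-hydroxyethyl)amino group, not replacing it. Compound 4 `COc1cc(C)cc2c1C(=O)C=C(c1c(C)cc3c(c1OC)C(=O)C(SCCO)=CC3=O)C2=O` differs from compound 2 by (2-hydroxyethyl)sulfanyl in place of (2-hydroxyethyl)amino on a double-bonded ring carbon. Within the data shown here, no measured pair shows this exchange, so the direction is open; a step within the scatter is expected, a 1.1-fold lower number from compound 2 to compound 4 (0.03 log units; within the scatter). Compound 4 is therefore estimated at 3000 nM, between 800 nM and 12000 nM.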

Compound 4, half-maximal inhibitory concentration: 190 nM
For compound 4 the middle estimate is 16-fold (1.20 log units) above the measured one; the measured number lies below the stated range.
By their numbers in this assay, from the lowest: compound 3; then compound 4; then compound 1; then compound 2.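

With the (2-hydroxyethyl) chain kept, putting (2-hydroxyethyl)sulfanyl in place of (2-hydroxyethyl)amino on the double-bonded ring carbon gives a 17-fold lower number from compound 2 to compound 4 (1.22 log units; beyond the scatter) in this assay. Within the data shown here, the earlier compounds showed only that adding a group at this carbon can shift the number; this step shows that the atom linking the chain to the ring carbon can shift it greatly on its own. Nothing available explains this difference.

Going by these compounds, whether the same exchange gives a similar step on the core of compound 3 remains open. So does the effect of an oxygen linker or a longer chain at this carbon.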